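Swapping the amide-ring substituent of compound 2 for a fluorinated one

The source may hold more compounds than are shown below. What is called first, only, known or untested is meant among the compounds shown, and "the series" means these compounds.

Three compounds sharing one core were tested in a functional assay on L02 cells (Homo sapiens) for inhibition, read by MTT assay, with a stated time of 48 h; a higher number here means a weaker inhibitor, a lower number a stronger inhibitor. Compound 1 is `O=C(/C=C/c1coc2cc(O)ccc2c1=O)NCc1ccccc1`. In this assay compound 1 gives only a limit of the assay, > 200000 nM. Compound 2 is `COc1ccc2c(=O)c(/C=C/C(=O)Nc3ccccc3Cl)coc2c1`. Compound 2 too reaches only the limit, > 200000 nM, so its position is known just as a bound and not as a number. Compound 3 is `COc1cccc(NC(=O)/C=C/c2coc3cc(OC)ccc3c2=O)c1`. Compound 3 likewise sits at the limit, > 200000 nM.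

The only measured step among these, a step that the two limits leave unreadable from compound 2 to compound 3, cannot be sized, because the limit of > 200000 nM in this assay, at which 3 of the 3 values shown sit, means both ends of it are bounds rather than numbers.

Compound 4 is `COc1ccc2c(=O)c(/C=C/C(=O)Nc3ccc(F)cc3)coc2c1`. Compared with compound 2 the change is 4-fluorophenyl in place of 2-chlorophenyl on an amide-type nitrogen. For the measured compounds named here, no measured step bears directly on this exchange, and the one step that is related, the change from compound 2 to compound 3, gives no readable size. What the three values do show is that every variation tried so far has left the core at the limit of the assay. On that basis compound 4 is expected to give 300000 nM, within a range from 150000 nM to 1000000 nM. The step that the limit leaves unreadable from compound 2 to compound 4 is therefore expected to be no larger than the scatter, with a high chance that only a limit is reported.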

Compound 4, half-maximal inhibitory concentration: > 200000 nM
Compound 4 gave a limit, no number (the forecaster's own chance of this, stated with the estimate: 85%); the middle value does not contradict the limit.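

Compound 4 sits at the limit of the assay, as compound 2 and compound 3 do, so neither step leading to compound 4 can be read, because both ends of each are limits and not numbers: the limit of > 200000 nM in this assay, at which 4 of the 4 values shown sit.

What stays open is how far any of these compounds lies beyond that limit in this assay, and whether any change to the shared core gives a readable value.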